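Working notes: 3,4,5-trimethoxyphenyl in place of 4-cyanophenyl

The source may report more compounds than this note shows. Statements on the series, on what has been measured and on what is new or still open speak of the compounds shown alone.

In an ADME assay on L02 cells (Homo sapiens) for cytotoxicity, read by MTT assay, with a stated time of 24 h (a lower number here means a stronger inhibitor, a higher number a weaker inhibitor), compound 1 (`COc1cc(/C=C2\CN(S(=O)(=O)c3ccc(NC(C)=O)cc3)C/C(=C\c3cc(OC)c(OC)c(OC)c3)C2=O)cc(OC)c1OC`) gives 13600 nM and compound 2 (`CC(=O)Nc1ccc(S(=O)(=O)N2C/C(=C\c3ccc(C#N)cc3)C(=O)/C(=C/c3ccccc3F)C2)cc1`) gives 14400 nM with the two values within the usual scatter of each other. For the measured compounds named here, compound 2 therefore does not stand apart from compound 1 on the numbers so far. Compound 3 (`COc1cc(/C=C2\CN(S(=O)(=O)c3ccc(NC(C)=O)cc3)C/C(=C\c3ccccc3F)C2=O)cc(OC)c1OC`) follows from compound 2 by this change: 3,4,5-trimethoxyphenyl in place of 4-cyanophenyl on a double-bonded chain carbon bound to a double-bonded ring carbon on a double-bonded chain carbon bound to a double-bonded ring carbon. Going by the values given here, no step between measured compounds is available. Compound 1 carries 3,4,5-trimethoxyphenyl at that place and gives 13600 nM so no step beyond the scatter is expected in this assay for this change. The estimated size is a 1.1-fold lower number from compound 2 to compound 3 (0.04 log units; within the scatter) and this is expected to stay within the scatter. For compound 3 the estimated value is 13000 nM with an expected range from 6000 nM to 27000 nM in this assay.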

Compound 3, half-maximal inhibitory concentration: 14000 nM
Compound 3: the middle estimate sits 1.1-fold (0.03 log units) below what was measured; the range from low to high includes it.
By their numbers in this assay, from the lowest: compounds 1, 3 and 2 (each within the scatter of the next).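

Both single changes now stand on their own, which the pair of compound 1 and compound 2 could not show, since those two differ in two places. In this assay, 3,4,5-trimethoxyphenyl in place of 4-cyanophenyl on a double-bonded chain carbon bound to a double-bonded ring carbon gives a 1.0-fold lower number from compound 2 to compound 3 (0.01 log units; within the scatter), and 2-fluorophenyl in place of 3,4,5-trimethoxyphenyl at such a place gives a 1.0-fold higher number from compound 1 to compound 3 (0.01 log units; within the scatter), so neither change separates from the scatter in these compounds. No measurement available here accounts for this result.

From the compounds shown here alone, whether a non-aromatic group at this place, such as an amine or a carboxylic acid on a short alkyl chain, would move the number beyond the scatter remains open. Also open, going by these compounds, is whether a change elsewhere on the shared core would do so.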